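Butoxy in Place of Methyl: Expected Cytotoxicity

The compounds below may be only part of what the source reports. "The series", "measured", "known", "first", "only" and "open" are said of these compounds alone.

Compound 1 `CCOC(=O)c1c(-c2cccc(C)c2)[nH]c2cc(OC)ccc2c1=O` was examined in an ADME assay on BJ cells (Homo sapiens) for cytotoxicity, read by luminescence, with a stated time of 72 h; a lower number here means that less compound is needed, a higher number that more compound is needed for the effect. Compound 1 gives > 21500 nM, which is a limit of the assay rather than a number. Compound 2 `CCOC(=O)c1c(-c2cccc(OC)c2)[nH]c2cc(OC)ccc2c1=O` gives > 21500 nM, also a limit. The step that the two limits leave unreadable from compound 1 to compound 2 therefore cannot be read. Compound 3 `CCCCOc1cccc(-c2[nH]c3cc(OC)ccc3c(=O)c2C(=O)OCC)c1` differs from compound 1 by butoxy in place of methyl on an aromatic carbon. Among the measured compounds shown here, the single measured step offers no readable size to lean on, since (the limit of > 21500 nM in this assay, at which 2 of the 2 values shown sit). Compound 3 is therefore expected to sit at that limit too, so the estimate for compound 3 is 30000 nM, within 10000 nM to 100000 nM, meaning an expected step that the limit leaves unreadable from compound 1 to compound 3.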

Compound 3, half-maximal effective concentration: > 21500 nM
Compound 3 gave a limit, no number; the forecaster's own chance of this, stated with the estimate: 75%; the middle value does not contradict the limit.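

No new step can be read between compound 1, compound 2 and compound 3, because each gives a limit rather than a number: the limit of > 21500 nM in this assay, at which 3 of the 3 values shown sit.

On these data alone, whether the methyl, methoxy and butoxy compounds differ at all on these cells stays open.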